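This account rests on a few compounds, and the source may have more. Where it says the series, first, only, none or still open, it means among the compounds named here.

In a functional assay on HL-60 cells (Homo sapiens) for antiproliferative activity, read by MTT assay, with a stated time of 72 h (a lower number here means a stronger inhibitor, a higher number a weaker inhibitor), compound 1 (`COc1cc(-n2ncnc2-c2ccc(OC(F)(F)F)cc2)cc(OC)c1OC`) gives > 10000 nM, which is a limit of the assay and not a number. Compound 2 (`COc1cc(-n2ncnc2-c2cccc(Cl)c2)cc(OC)c1OC`) gives > 10000 nM, also a limit. Compound 2 thus stands at the limit of > 10000 nM in this assay, at which 2 of the 2 values shown sit. Compound 3 (`COc1cc(-n2ncnc2-c2ccc(SC)cc2)cc(OC)c1OC`) carries 4-(methylsulfanyl)phenyl in place of 3-chlorophenyl on an aromatic carbon. No measured step sizes this change, so only a modest move towards stronger inhibition is expected, and another limit remains quite possible. The expected change is an at least 2.5-fold lower number from compound 2 to compound 3 (0.39 log units; beyond the scatter). For compound 3 the estimated value is 4000 nM, with an expected range of 300 nM to 10000 nM.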

Compound 3, half-maximal inhibitory concentration: 500 nM
Estimate against measurement, compound 3: 8.0-fold (0.90 log units) above; the measured number falls inside the stated range.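

In this assay, the aryl group on this aromatic carbon decides whether a value can be read at all: 4-(methylsulfanyl)phenyl in place of 3-chlorophenyl brings an at least 20-fold lower number from compound 2 to compound 3 (1.30 log units; beyond the scatter). Methylsulfanyl in place of trifluoromethoxy brings an at least 20-fold lower number from compound 1 to compound 3 (1.30 log units; beyond the scatter). Both steps start from a limit, so their full size remains unknown: the limit of > 10000 nM in this assay, at which 2 of the 3 values shown sit.

The compounds shown leave open whether the sulfur atom itself is needed, since a methoxy or dimethylamino group in its place would test that. A longer chain on the sulfur, such as ethylsulfanyl, is also an open case.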